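Chlorine Between the Ring Nitrogens: A Repeated Step

The source may report more compounds than this note shows. Statements on the series, on what has been measured and on what is new or still open speak of the compounds shown alone.

Three purine-type compounds have been measured in a functional assay on MOLT-4 cells (Homo sapiens) for cytotoxicity, read by sulforhodamine B assay, with a stated time of 48 h; on this read-out lower numbers stand for stronger inhibition of growth and higher numbers for weaker inhibition of growth. Compound 1 `ClCc1ccccc1Cn1cnc2c(Cl)nc(Cl)nc21` gives 200 nM. Compound 2 `ClCc1ccccc1Cn1cnc2c(Cl)ncnc21` gives 1580 nM. Compound 3 `ClCc1cccc(Cn2cnc3ncnc(Cl)c32)c1` gives 10700 nM, the highest of the three numbers. Compound 1 differs from compound 2 by a single change, (chloro in place of hydrogen on an aromatic carbon), and this change produced a 7.9-fold lower number from compound 2 to compound 1 (0.90 log units; beyond the scatter). Compound 3 and compound 2 share the same atoms joined differently; the difference between the two cores is not broken down here, and their values simply stand as given.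

Compound 4 `ClCc1cccc(Cn2cnc3nc(Cl)nc(Cl)c32)c1` has not yet been measured in this assay. Among the compounds with values here, it differs from compound 3 by chloro in place of hydrogen on an aromatic carbon, which is the same change, at the same kind of place word for word, as the one that separates compound 2 from compound 1. Within the data shown here, there is only one measured instance of this change, so the expectation rests on that single step and carries the usual uncertainty.

In this assay compound 4 is expected to give about 1500 nM, with a range from 500 nM to 4500 nM. The estimated step is a 7.1-fold lower number from compound 3 to compound 4 (0.85 log units; beyond the scatter), resting on the earlier observation that compound 1 gained over compound 2 by a 7.9-fold lower number from compound 2 to compound 1 (0.90 log units; beyond the scatter).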

Compound 4, concentration for 50% growth inhibition: 1040 nM
Beside the measured number, compound 4's estimate is 1.4-fold (0.16 log units) above it; the range from low to high includes it.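

In this assay, chloro in place of hydrogen on an aromatic carbon, between two ring nitrogen atoms, gave a 10-fold lower number from compound 3 to compound 4 (1.01 log units; beyond the scatter). Set beside the earlier step, the change carried from one core to the other with no difference that these data can separate: the same change on two cores in this assay, a 7.9-fold lower number (0.90 log units; beyond the scatter) from compound 2 to compound 1 and a 10-fold lower number (1.01 log units; beyond the scatter) from compound 3 to compound 4, 1.3-fold (0.11 log units) apart, within the scatter of two such steps. Within the data shown here, this agreement rests on only two pairs of compounds in a single cell line, so it does not show that the step would hold on any further core, and it says nothing about why the chloro group acts as it does here.

All the compounds shown carry either hydrogen or chloro at this place, which leaves open whether an amine, a methoxy group or a bromo group there would give a step of similar size. As far as these compounds go, all of them also keep the chloromethyl group, so it remains open how the two cores would respond with a hydroxymethyl or a plain methyl group in its stead.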